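This account rests on a few compounds, and the source may have more. Where it says the series, first, only, none or still open, it means among the compounds named here.

Measured so far:
- compound 1 `C#CCN(Cc1ccc2nc(C)nc(O)c2c1)c1ccc([N+](=O)[O-])cc1`: 4700 nM
- compound 2 `C#CCN(Cc1ccc2nc(C)nc(O)c2c1)c1ccc(S(=O)(=O)C(F)(F)F)cc1`: 2750 nM

Both compounds were tested in a functional assay on L1210 cells (Mus musculus) for inhibition; on this read-out lower numbers stand for stronger inhibition and higher numbers for weaker inhibition. Within the data shown here, compound 2 gives 2750 nM and compound 1 gives 4700 nM, so compound 2 cannot be told apart from the only other compound measured.

Compound 3 `C#CCN(Cc1ccc2nc(C)nc(O)c2c1)c1ccc(S(=O)(=O)N2CCOCC2)cc1` keeps the shared core and the sulfonyl but changes the group attached to it: morpholin-4-yl in place of trifluoromethyl on a sulfonyl sulfur. In words, this is morpholin-4-yl in place of trifluoromethyl on a sulfonyl sulfur.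

Among the measured compounds shown here, only one measured step bears on this change, and only indirectly. It swaps nitro in compound 1 for (trifluoromethyl)sulfonyl in compound 2 and amounts to a 1.7-fold lower number from compound 1 to compound 2 (0.23 log units; within the scatter). For the measured compounds named here, no measured step changes a group on the sulfonyl sulfur itself, so the direction remains open and the range must stay wide. With that single small step as the guide, no shift beyond the scatter is expected.

The expected step is a 1.3-fold higher number from compound 2 to compound 3 (0.10 log units; within the scatter).

The estimate for compound 3 is 3500 nM, with an expected range of 1200 nM to 10000 nM.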

Compound 3, half-maximal inhibitory concentration: 3100 nM
Compound 3: the middle estimate sits 1.1-fold (0.05 log units) above what was measured; measured number inside the range.
By their numbers in this assay, from the lowest: compounds 2, 3 and 1 (each within the scatter of the next).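

In this assay, putting morpholin-4-yl in place of trifluoromethyl on the sulfonyl sulfur gives a 1.1-fold higher number from compound 2 to compound 3 (0.05 log units; within the scatter). This is the first change shown on the sulfur itself, and although it brings in a six-membered non-aromatic ring with a hydrogen-bond acceptor, the read-out does not separate the two compounds. Exchanging nitro on the aromatic carbon for the whole (morpholin-4-yl)sulfonyl group gives a 1.5-fold lower number from compound 1 to compound 3 (0.18 log units; within the scatter), so all three groups now sit within the scatter of one another, and nothing measured on these compounds explains this flat result.

The compounds shown leave open whether any group at this place can move the number beyond the scatter, since three different groups have so far given values that cannot be told apart. A small open-chain amine such as dimethylamino on the sulfonyl sulfur, or a carboxylic acid in place of the whole sulfonyl group on the aromatic carbon, would show whether the read-out responds to a more different group here.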